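Swapping the Outer Aryl Ring: Compound 2 to Compound 4

A few compounds are considered here, and "the series" means these few. Any claim that something is new, unique, unknown or untested is made for them only; others in the source may bear on it.

Of the compounds shown here, three that share one core have been measured in a physicochemical assay for lipophilicity, read by HPLC, at pH 7.5; a higher number here means a more lipophilic compound, a lower number a more polar compound. Compound 1 `CCOc1ccccc1-c1ccc(-c2nc3cnccc3c(N[C@H](CC)C(=O)N(C)C)c2C#N)cc1` gives 3.7. Compound 3 `CCCCC(Nc1c(C#N)c(-c2ccc(-c3ccccc3OCC)cc2)nc2cnccc12)C(N)=O` gives 3.6; the step of a number 0.10 log units lower from compound 1 to compound 3 (within the scatter) shows that exchanging the amide side chain on the ring nitrogen barely moves this assay. Compound 2 `CC[C@@H](Nc1c(C#N)c(-c2ccc(-c3ccc(OC)cc3)cc2)nc2cnccc12)C(N)=O` gives 2.7, the lowest of the three, sitting well below both compound 3 and compound 1.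

Compound 4 `CC[C@@H](Nc1c(C#N)c(-c2ccc(-c3ccccc3C(C)C)cc2)nc2cnccc12)C(N)=O` is not yet measured. It differs from compound 2 in one place: 2-isopropylphenyl in place of 4-methoxyphenyl on an aromatic carbon. For the measured compounds named here, no measured step addresses this change; the only step recorded, from compound 1 to compound 3, concerns the amide and is within the scatter. The group that leaves carries one hydrogen-bond acceptor and one oxygen; the group that enters is carbon only, with no acceptor. On that basis the step from compound 2 to compound 4 is expected to be an increase beyond the scatter, a number 1.10 log units higher from compound 2 to compound 4 (beyond the scatter). Compound 4 is therefore estimated at 3.8, in a range from 3.3 to 4.3.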

Compound 4, distribution coefficient: 3.5
Compound 4: the middle estimate sits 0.30 log units above what was measured; the measured number falls inside the stated range.
By their numbers in this assay, from the lowest: compound 2; then compounds 4, 3 and 1 (each within the scatter of the next).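

For the compounds shown here, measured by this assay the exchange of 4-methoxyphenyl for 2-isopropylphenyl gives a number 0.80 log units higher from compound 2 to compound 4 (beyond the scatter) and is the first change at this position to be read directly. The only earlier step concerned the amide side chain and stayed within the scatter, so this is the first single change among these compounds shown to move the number beyond it. Nothing available here accounts for the size of this step.

The exchange alters both the group on the outer ring and where that group sits, and the compounds shown do not separate the two; a 2-methoxyphenyl or a 4-isopropylphenyl group on the same core with the same side chain would do so. As far as these compounds go, how an outer ring carrying an amine or a carboxylic acid would read also remains open.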